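The source may report more compounds than this note shows. Statements on the series, on what has been measured and on what is new or still open speak of the compounds shown alone.

Compound 1 `CC1(C)C/C(=N\OC(=O)c2cccc(NC(=O)c3cccc(F)c3)c2)c2c(-c3ccc(F)cc3)noc2C1` and compound 2 `CC1(C)C/C(=N\OC(=O)c2cccc(NC(=O)c3cccc(F)c3)c2)c2c(-c3cccc(F)c3)noc2C1` share one core and differ only in the fluorophenyl group attached to it. In a functional assay on MCF7 cells (Homo sapiens) for antiproliferative activity, read by MTT assay, with a stated time of 72 h (on this read-out lower numbers stand for stronger inhibition and higher numbers for weaker inhibition), compound 1 gives 5200 nM, while compound 2 gives 25000 nM, the higher of the two numbers. The step of a 4.8-fold higher number from compound 1 to compound 2 (0.68 log units; beyond the scatter) shows that this ring is a sensitive part of the molecule. Compound 3 `COc1ccc(-c2noc3c2/C(=N/OC(=O)c2cccc(NC(=O)c4cccc(F)c4)c2)CC(C)(C)C3)cc1OC` carries 3,4-dimethoxyphenyl in place of 3-fluorophenyl on an aromatic carbon. For the measured compounds named here, no measured step matches this swap, and the one known step only signals that changes at this ring can matter, so the direction is open. Compound 3 is expected to give 15000 nM, within a range of 3000 nM to 60000 nM. This estimate corresponds to an expected 1.7-fold lower number from compound 2 to compound 3 (0.22 log units; within the scatter).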

Compound 3, half-maximal inhibitory concentration: > 25000 nM
Compound 3: a limit, no number; the forecaster's own chance of this, stated with the estimate: 25%; at least 1.6-fold (0.22 log units) between middle value and limit.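

For compound 3 the reading is a limit and not a number: the limit of > 25000 nM in this assay, at which 1 of the 3 values shown sits.

Replacing 4-fluorophenyl with 3,4-dimethoxyphenyl gives an at least 4.8-fold higher number from compound 1 to compound 3 (0.68 log units; beyond the scatter), so this larger ring, which carries two oxygens instead of a fluorine, does not match compound 1. Replacing 3-fluorophenyl with 3,4-dimethoxyphenyl gives a number no lower from compound 2 to compound 3 (the limit leaves the size open), so compound 1 remains the only one of the three with a clearly lower number.

As far as these compounds go, it remains open how a single methoxy group would behave on this ring, and whether an amine or a carboxylic acid there would bring the number down.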